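This account rests on a few compounds, and the source may have more. Where it says the series, first, only, none or still open, it means among the compounds named here.

In an ADME assay on J774 cells (Mus musculus) for cytotoxicity (a higher number here means that more compound is needed for the effect, a lower number that less compound is needed), compound 1 `COC(=O)c1c[nH]c2ccc(OCCc3ccccc3)cc2c1=O` gives 2200 nM. Compound 2 `COC(=O)c1c[nH]c2ccc(-c3ccccc3)cc2c1=O` stands at > 20000 nM, which is a limit of the assay and not a number. Compound 3 `COC(=O)c1c[nH]c2ccc(Oc3ccccc3)cc2c1=O` has not yet been measured and differs from compound 2 in one place: phenoxy in place of phenyl on an aromatic carbon. Among the compounds with values here, no measured step isolates this change, so the expectation rests on few data. Compound 1 also links its phenyl ring through oxygen and reads 2200 nM, so compound 3 is expected to need less compound than compound 2 in this assay. The estimated change is an at least 2.2-fold lower number from compound 2 to compound 3 (0.34 log units; beyond the scatter), a moderate step beyond the scatter toward less compound needed. For compound 3 the estimated value is 9000 nM, with an expected range of 3500 nM to 20000 nM.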

Compound 3, half-maximal effective concentration: > 20000 nM
Compound 3: a limit, no number; the forecaster's own chance of this, stated with the estimate: 35%; middle value at least 2.2-fold (0.34 log units) away from the limit.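

In this assay compound 3 stands at > 20000 nM, which is a limit of the assay and not a number. Phenyl in place of phenethyl on the oxygen gives an at least 9.0-fold higher number from compound 1 to compound 3 (0.95 log units; beyond the scatter), so the oxygen link alone does not carry the lower number of compound 1, and the phenethyl group on that oxygen goes with it. The step from phenyl to phenoxy cannot be read, because compound 2 and compound 3 stand at the same limit: the limit of > 20000 nM in this assay, at which 2 of the 3 values shown sit.

Open, as far as these compounds go, is where between phenyl and phenethyl on this oxygen the number starts to fall, which a benzyl group would help to show, and whether a longer chain such as phenylpropyl lowers it further. Also open, from the compounds shown here alone, is how far beyond the limit compound 2 and compound 3 lie, and whether they differ at all.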